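A ring exchange on the carbonyl carbon of compound 2

A few compounds are considered here, and "the series" means these few. Any claim that something is new, unique, unknown or untested is made for them only; others in the source may bear on it.

Two compounds have so far been measured in a functional assay (aorta) with Rattus norvegicus as the target; a lower number here means that less compound is needed, a higher number that more compound is needed for the effect

Compound 1 `COc1ccc(-c2nc(/N=C(\N)[N+]3(C)CCCCC3)sc2-c2ccc(OC)cc2)cc1` gives 21 uM
Compound 2 `COc1ccc(-c2nc(CNC(=O)c3cccnc3)sc2-c2ccc(OC)cc2)cc1` gives 8.2 uM

Compound 2 holds the lower of these two numbers. Within the data shown here, the only measured step (a 2.6-fold lower number from compound 1 to compound 2 (0.41 log units; beyond the scatter)) is modest and concerns a group on an aromatic carbon, so it serves only as a guide to size. Among the measured compounds shown here, compound 3 (`COc1ccc(-c2nc(CNC(=O)C3=NNC(=O)CC3)sc2-c2ccc(OC)cc2)cc1`) differs from compound 2 by a group of 7 heavy atoms (4 carbon, 2 nitrogen, 1 oxygen; one six-membered non-aromatic ring with 2 hetero atoms) in place of a group of 6 heavy atoms (5 carbon, 1 nitrogen; one six-membered aromatic ring with 1 hetero atom), on a carbonyl carbon and no measured step covers this exchange. No firm direction can be drawn, and the expected step (a 1.2-fold higher number from compound 2 to compound 3 (0.09 log units; within the scatter)) stays within the scatter. In this assay compound 3 is expected at 10 uM with 3 uM and 30 uM as the ends of the estimated range.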

Compound 3, concentration for half-maximal effect: 7.3 uM
The estimate for compound 3 lay 1.4-fold (0.14 log units) above the measured number, and the stated range covers the measured number.
By their numbers in this assay, from the lowest: compounds 3 and 2 (each within the scatter of the next); then compound 1.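

On the carbonyl carbon, the pyridin-3-yl group can give way to a six-membered non-aromatic ring with 2 hetero atoms with no readable change in this assay, which shows a 1.1-fold lower number from compound 2 to compound 3 (0.05 log units; within the scatter). The aromatic ring of compound 2 is therefore not required at this position for a number in this range, and the added hydrogen-bond donor of compound 3 brings no readable change either. No available evidence accounts for this result.

As far as these compounds go, whether a group without a ring, such as an amine or a carboxylic acid on this carbonyl carbon, would hold the number in this range remains open. So does the effect of a plain phenyl ring there.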